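A few compounds are considered here, and "the series" means these few. Any claim that something is new, unique, unknown or untested is made for them only; others in the source may bear on it.

Compound 1 `COc1ccc(/C=N/NC(=O)c2ccc(C)cc2O)cc1` gives only a limit of the assay in a functional assay (Mus musculus, strain BALB/C) for inhibition, read by MTT assay, with stated times of 24 h and 72 h (on this read-out higher numbers stand for weaker inhibition and lower numbers for stronger inhibition), namely > 100000 nM. Compound 2 `Cc1ccc(C(=O)N/N=C/c2ccc(Cl)cc2Cl)c(O)c1` gives 9780 nM in this assay. Compound 3 `Cc1ccc(C(=O)N/N=C/c2ccc(Cl)cc2)c(O)c1` gives 12300 nM in this assay.

Compound 3 holds the highest of the two numbers shown, with compound 2 nearest and within the scatter; the value of compound 1 is a limit. Compound 4 `Cc1ccc(C(=O)N/N=C/c2ccc([N+](=O)[O-])cc2)c(O)c1` differs from compound 3 by nitro in place of chloro on an aromatic carbon. Of the measured steps, only an at least 8.1-fold lower number from compound 1 to compound 3 (0.91 log units; beyond the scatter) changes the same position, and a 1.3-fold higher number from compound 2 to compound 3 (0.10 log units; within the scatter) concerns a different site; neither brings in a nitro group. The expectation for compound 4 is therefore a step of a 1.2-fold higher number from compound 3 to compound 4 (0.09 log units; within the scatter), not beyond the scatter. Compound 4 is estimated at 15000 nM, with a range from 5000 nM to 60000 nM.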

Compound 4, half-maximal inhibitory concentration: 24300 nM
Compound 4: middle estimate off by 1.6-fold (0.21 log units), on the low side, within the range that was stated.
By their numbers in this assay, from the lowest: compounds 2, 3 and 4 (each within the scatter of the next, the first and the last beyond it). At a limit, above all of these: compound 1.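

With a 2.0-fold higher number from compound 3 to compound 4 (0.30 log units; within the scatter) in this assay nitro takes the place of chloro on this aromatic carbon, and the change stays within the scatter. The value of compound 1 is a limit of the assay. Against that limit, an at least 4.1-fold lower number from compound 1 to compound 4 (0.61 log units; beyond the scatter) places nitro with chloro, clear of methoxy at this position. The compounds shown leave open whether an amine or a carboxylic acid on this carbon would stay with chloro and nitro or would go with methoxy.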